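Swapping the Benzodioxin for a Bromophenyl Group

This account rests on a few compounds, and the source may have more. Where it says the series, first, only, none or still open, it means among the compounds named here.

Measured compounds:
Compound 1 `COc1ccc(CNCCCNS(=O)(=O)c2cc(C(F)(F)F)cc(C(F)(F)F)c2)cc1OC` — in a functional assay on HPAC cells (Homo sapiens) for inhibition, read by MTT assay, with a stated time of 72 h (a lower number here means a stronger inhibitor of growth, a higher number a weaker inhibitor of growth), compound 1 gives 3500 nM
Compound 2 `O=S(=O)(NCCCNCC1COc2ccccc2O1)c1cc(C(F)(F)F)cc(C(F)(F)F)c1` — in this assay compound 2 gives 2700 nM

Compound 2 has the lower of the two numbers, yet a 1.3-fold lower number from compound 1 to compound 2 (0.11 log units; within the scatter), so the two stand level. Compound 3 `O=S(=O)(NCCCNCc1ccc(Br)cc1)c1cc(C(F)(F)F)cc(C(F)(F)F)c1` is not yet measured; it differs from compound 2 by 4-bromophenyl in place of 2,3-dihydro-1,4-benzodioxin-2-yl on a saturated chain carbon bound to an amine nitrogen. Among the measured compounds shown here, the one measured step, a 1.3-fold lower number from compound 1 to compound 2 (0.11 log units; within the scatter), changed the same group at the same place and stayed within the scatter. For compound 3 the estimate is therefore a step of a 1.1-fold higher number from compound 2 to compound 3 (0.05 log units; within the scatter), nothing beyond the scatter. Compound 3 is expected to give about 3000 nM, within 1200 nM to 8000 nM.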

Compound 3, concentration for 50% growth inhibition: 2900 nM
For compound 3 the middle estimate is 1.0-fold (0.01 log units) above the measured one; the measured number falls inside the stated range.
By their numbers in this assay, from the lowest: compounds 2, 3 and 1 (each within the scatter of the next).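

In this assay, 4-bromophenyl stands level with both earlier groups at this place, on a saturated chain carbon bound to an amine nitrogen (a 1.1-fold higher number from compound 2 to compound 3 (0.03 log units; within the scatter); a 1.2-fold lower number from compound 1 to compound 3 (0.08 log units; within the scatter)). The place therefore accepts a group with 0 hydrogen-bond acceptors and 7 heavy atoms as well as 2,3-dihydro-1,4-benzodioxin-2-yl, which has 2 hydrogen-bond acceptors and 10 heavy atoms. No measurement here accounts for this. Going by these compounds, whether a pyridine ring, a carboxylic acid or a simple methyl at this place would move the number beyond the scatter stays open. So does the effect of a longer chain.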